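The source may hold more compounds than are shown below. What is called first, only, known or untested is meant among the compounds shown, and "the series" means these compounds.

Of the compounds shown here, three built on one shared core have been measured in an assay on V79MZh11B1 cells for inhibition of cytochrome P450 11B1, mitochondrial (Homo sapiens), read by HPLC, with a stated time of 25 min; on this read-out lower numbers stand for stronger inhibition and higher numbers for weaker inhibition. Compound 1 `O=c1cc(Cn2ccnc2)c2ccc(OCc3cccc(Cl)c3)cc2o1` carries a chloro group on its benzyl ring and gives 31 nM. Compound 2 `O=c1cc(Cn2ccnc2)c2ccc(OCc3cccc(C(F)(F)F)c3)cc2o1` carries trifluoromethyl at the same position and gives 20 nM. Compound 3 `COc1cccc(COc2ccc3c(Cn4ccnc4)cc(=O)oc3c2)c1` carries methoxy there and gives 48 nM. Going by the values given here, of the three numbers, that of compound 3 is the largest, yet the step of a 1.5-fold higher number from compound 1 to compound 3 (0.19 log units; within the scatter) stays within the scatter, and only the step of a 2.4-fold higher number from compound 2 to compound 3 (0.38 log units; beyond the scatter) reaches beyond it.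

Compound 4 `O=c1cc(Cn2ccnc2)c2ccc(OCc3cccc(F)c3)cc2o1` is the next member, and the change from compound 3 is fluoro in place of methoxy on an aromatic carbon, on an aromatic carbon of a six-membered aromatic ring of carbon only, meta to a large group. Among the compounds with values here, the steps that bear on it are the exchanges at this same carbon: a 1.6-fold lower number from compound 1 to compound 2 (0.19 log units; within the scatter), a 1.5-fold higher number from compound 1 to compound 3 (0.19 log units; within the scatter) and a 2.4-fold higher number from compound 2 to compound 3 (0.38 log units; beyond the scatter). Two halogen-type substituents gave numbers within the scatter of each other or only modestly apart from methoxy, so the move to fluoro is expected to bring at most a modest lowering of the number, or none beyond the scatter. Compound 4 is therefore estimated at 35 nM in this assay, with a range from 15 nM to 80 nM, an expected step of a 1.4-fold lower number from compound 3 to compound 4 (0.14 log units; within the scatter).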

Compound 4, half-maximal inhibitory concentration: 40 nM
Compound 4: the middle estimate sits 1.1-fold (0.06 log units) below what was measured, and the stated range covers the measured number.
By their numbers in this assay, from the lowest: compounds 2, 1, 4 and 3 (each within the scatter of the next, the first and the last beyond it).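

In this assay, exchanging methoxy, with its 2 heavy atoms and 1 hydrogen-bond acceptor, for fluoro, with 1 heavy atom and no hydrogen-bond acceptor, gives a step within the scatter (a 1.2-fold lower number from compound 3 to compound 4 (0.08 log units; within the scatter)), and the exchange of chloro for fluoro is also within it (a 1.3-fold higher number from compound 1 to compound 4 (0.11 log units; within the scatter)). Even the step from trifluoromethyl to fluoro stays within the scatter (a 2.0-fold higher number from compound 2 to compound 4 (0.30 log units; within the scatter)), so compound 4 adds a fourth group at this carbon without widening the spread of the numbers, and the only step beyond the scatter among these four compounds remains the one between compound 2 and compound 3. The data shown offer no independent finding that would explain why these four groups give such closely spaced numbers.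

The compounds shown leave open whether an amine, a carboxylic acid or a longer chain such as butoxy on this same carbon would keep the number in this narrow band. On these data alone, it also remains open what chloro, trifluoromethyl, methoxy or fluoro would give on any other carbon of this ring.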